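This account rests on a few compounds, and the source may have more. Where it says the series, first, only, none or still open, it means among the compounds named here.

Series notes. Two compounds have numbers in a functional assay on EKVX cells (Homo sapiens) for cytotoxicity, read by sulforhodamine B assay, with a stated time of 48 h; on this read-out lower numbers stand for higher toxicity in this test and higher numbers for lower toxicity in this test. Compound 1 `ClCc1ccccc1Cn1cnc2c(Cl)ncnc21` gives 37200 nM in this assay. Compound 2 `ClCc1ccc(Cn2cnc3nc(Cl)nc(Cl)c32)cc1` gives 6300 nM in this assay, the lowest of the two numbers; its gap to compound 1 lies beyond the scatter. These two differ in more than one place, so no single step is computed between them and only the two numbers themselves are shown.

Compound 3 `ClCc1ccc(Cn2cnc3ncnc(Cl)c32)cc1` has not been measured in this assay. It differs from compound 2 by hydrogen in place of chloro on an aromatic carbon, that carbon sitting between two ring nitrogen atoms of the six-membered aromatic ring of the fused system. Among the measured compounds shown here, no measured pair shows this change, so its size in this assay is unknown from the data. The working expectation is a modest rise in the number, a loss of toxicity, of a size that may or may not exceed the scatter. Compound 3 is therefore estimated at 14000 nM, with a range from 5000 nM to 40000 nM, which corresponds to an expected step of a 2.2-fold higher number from compound 2 to compound 3 (0.35 log units; beyond the scatter).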

Compound 3, concentration lethal to 50% of the cells: 8700 nM
Estimate against measurement, compound 3: 1.6-fold (0.21 log units) above; the measured number falls inside the stated range.
By their numbers in this assay, from the lowest: compounds 2 and 3 (each within the scatter of the next); then compound 1.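

In this assay, among the compounds shown here, hydrogen in place of chloro on the aromatic carbon between two ring nitrogen atoms gives a 1.4-fold higher number from compound 2 to compound 3 (0.14 log units; within the scatter), the first single-change reading at this position, which compound 1 and compound 2 could not provide. In this one pair, with the other chloro group and the chloromethyl group held constant, the chloro at this position is not required for the toxicity seen in this test. Nothing available explains this outcome.

The compounds shown leave open how other groups on this carbon, such as an amine or a methoxy group, would read. They also leave open what happens when the remaining chloro on the same ring gives way to hydrogen or an amine, or when the chloromethyl group gives way to a plain methyl group.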